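Azide in place of chloride on a macrocyclic enone scaffold

This account rests on a few compounds, and the source may have more. Where it says the series, first, only, none or still open, it means among the compounds named here.

The study compares two measured macrocycles and one not yet measured. Compound 1 `CC(=O)OC/C1=C/C[C@](C)(CCC=C(C)C)/C=C/[C@@H](OC(=O)C=C(C)C)[C@](C)(OC(C)=O)/C=C/C1=O` carries acetate groups on the shared core; in a functional assay on A549 cells (Homo sapiens) for antiproliferative activity, read by MTT assay, with a stated time of 48 h (a lower number here means a stronger inhibitor, a higher number a weaker inhibitor), compound 1 gives 15100 nM. Compound 2 `CC(C)=CCC[C@]1(C)/C=C/[C@@H](OC(=O)C=C(C)C)[C@](C)(O)/C=C/C(=O)/C(CCl)=C\C1` instead bears a free hydroxyl and a chloromethyl group on the enone; in this assay compound 2 gives 150 nM. Among the two numbers, compound 2 stands lowest, and its distance from compound 1 lies beyond the scatter. The unmeasured compound 3 `CC(C)=CCC[C@]1(C)/C=C/[C@@H](OC(=O)C=C(C)C)[C@](C)(O)/C=C/C(=O)/C(CN=[N+]=[N-])=C\C1` differs from compound 2 in one place: azido in place of chloro on a saturated chain carbon bound to a double-bonded ring carbon. Going by the values given here, no measured pair shows this exchange, so the size of the step is uncertain. Since compound 2 already gives 150 nM, a modest move toward a higher number is expected, the chloro-to-azido change being treated as roughly neutral to slightly weakening. For compound 3 in this assay the estimated value is 400 nM, with a range from 100 nM to 2000 nM. The step this estimate implies, a 2.7-fold higher number from compound 2 to compound 3 (0.43 log units; beyond the scatter), is expected to stay near the edge of the scatter.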

Compound 3, half-maximal inhibitory concentration: 1720 nM
Estimate against measurement, compound 3: 4.3-fold (0.63 log units) below; measured number inside the range.
By their numbers in this assay, from the lowest: compound 2; then compound 3; then compound 1.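

In this assay, the exchange of chloro for azido on a saturated chain carbon bound to a double-bonded ring carbon gives an 11-fold higher number from compound 2 to compound 3 (1.06 log units; beyond the scatter), a large change from a single replacement. Going by these compounds alone, compound 1 differs from compound 2 in more than one place, so this pair is the first to isolate this position, and it shows that the group on this carbon can by itself shift the number well beyond the scatter while the rest of the molecule stays the same. Nothing available explains why azidomethyl gives a higher number here than chloromethyl.

A single pair cannot tell whether the step reflects the loss of chloro or the arrival of azido, and the compounds shown leave open how a bromo group, an amine or a plain methyl group on the same carbon would read in this assay. They also leave open whether the same exchange would produce a step of similar size on a molecule carrying the acetate groups of compound 1.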